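A few compounds are considered here, and "the series" means these few. Any claim that something is new, unique, unknown or untested is made for them only; others in the source may bear on it.

Three compounds sharing one core were tested in a toxicity assay on MDCK cells (Canis lupus familiaris) for cytotoxicity, read by crystal violet staining, with a stated time of 48 h; a lower number here means that less compound is tolerated, a higher number that more compound is tolerated. Compound 1 `COc1ccc(CN(Cc2ccc(C(C)(C)C)cc2)Cc2cc3cc(C)ccc3[nH]c2=O)cc1` gives > 10000 nM in this assay, which is a limit rather than a number. Compound 2 `Cc1ccc2[nH]c(=O)c(CN(Cc3ccc(OC(F)F)cc3)Cc3ccc(C(C)(C)C)cc3)cc2c1` gives > 5000 nM in this assay, again a limit. Compound 3 `COc1ccc(C(C)N(Cc2ccc(C(C)(C)C)cc2)Cc2cc3cc(C)ccc3[nH]c2=O)cc1` gives > 5000 nM in this assay, also a limit. The change difluoromethyl in place of methyl on an oxygen on an aromatic ring gave the step that the two limits leave unreadable from compound 1 to compound 2. Compound 4 `Cc1ccc2[nH]c(=O)c(CN(Cc3ccc(C(C)(C)C)cc3)C(C)c3ccc(OC(F)F)cc3)cc2c1` carries the same change on the core of compound 3, namely (difluoromethyl in place of methyl on an oxygen on an aromatic ring). The two cores differ in that (methyl in place of hydrogen on a saturated chain carbon bound to an amine nitrogen and an aromatic carbon). Because every value sits at a limit of > 10000 nM in this assay, at which 1 of the 3 values shown sits (the limit of > 5000 nM in this assay, at which 2 of the 3 values shown sit), the earlier step has no readable size, so for compound 4 the step is expected to be a step that the limit leaves unreadable from compound 3 to compound 4. Compound 4 is therefore estimated at 10000 nM in this assay, most likely between 3000 nM and 30000 nM.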

Compound 4, half-maximal cytotoxic concentration: > 5000 nM
Compound 4: only a limit was reported (the forecaster's own chance of this, stated with the estimate: 85%); the middle value is on the limit's open side.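

For the compounds shown here, compound 1, compound 2, compound 3 and compound 4 are all reported only as limits, so no step among them can be read. From the compounds shown here alone, the half-maximal cytotoxic concentration of each compound in this assay remains open.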